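The compounds below may be only part of what the source reports. "The series", "measured", "known", "first", "only" and "open" are said of these compounds alone.

Compound 1 `Fc1ccc2[nH]c(-c3cn(-c4ccccc4)nc3-c3ccccc3)nc2c1`: 1720 nM
Compound 2 `Fc1ccc(-c2nn(-c3ccccc3)cc2-c2nc3ccccc3[nH]2)cc1`: 1510 nM

In a functional assay on A549 cells (Homo sapiens) for antiproliferative activity, read by MTT assay, with a stated time of 48 h (on this read-out lower numbers stand for stronger inhibition and higher numbers for weaker inhibition), compound 2 gives 1510 nM, which lies within the scatter of compound 1 at 1720 nM. Compound 3 `Fc1ccc(-c2nn(-c3ccccc3)cc2-c2nc3cc(F)ccc3[nH]2)cc1` has fluoro in place of hydrogen on an aromatic carbon of the six-membered aromatic ring of carbon only, part of a fused or bridged system of two rings (fluoro in place of hydrogen on an aromatic carbon). Among the measured compounds shown here, no measured step covers this change, but compound 1 also carries fluoro on that ring system. No step beyond the scatter is expected, and no direction can be expected with confidence. The expected step is a 1.2-fold lower number from compound 2 to compound 3 (0.07 log units; within the scatter). For compound 3 the estimated value is 1300 nM, with an expected range of 550 nM to 3000 nM.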

Compound 3, half-maximal inhibitory concentration: 1130 nM
Compound 3: middle estimate off by 1.2-fold (0.06 log units), on the high side; the measured number falls inside the stated range.
By their numbers in this assay, from the lowest: compounds 3, 2 and 1 (each within the scatter of the next).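

In this assay, fluoro in place of hydrogen on the six-membered aromatic ring of carbon only gives a 1.3-fold lower number from compound 2 to compound 3 (0.13 log units; within the scatter) and so leaves the number within the scatter at this position. Compound 3 carries both the fluoro groups that compound 1 and compound 2 carry singly, and a 1.5-fold lower number from compound 1 to compound 3 (0.18 log units; within the scatter) shows that the second fluoro also gives no step beyond the scatter. Nothing measured here bears on why these steps are so small.

On these data alone, whether a larger group at this position, such as an amine, a methoxy group or a carboxylic acid, would give a step beyond the scatter stays open.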